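From a Limit Toward a Number: Compound 3

The compounds below may be only part of what the source reports. "The series", "measured", "known", "first", "only" and "open" are said of these compounds alone.

In a functional assay on MDA-MB-231 cells (Homo sapiens) for antiproliferative activity, read by MTT assay, with a stated time of 24 h (on this read-out lower numbers stand for stronger inhibition and higher numbers for weaker inhibition), compound 1 `O=C(NNc1ccccc1F)c1cccc(NS(=O)(=O)c2cnc(O)nc2O)c1` gives no exact number, only a limit of > 20000 nM. So its true potency on this scale remains unknown. Going by the values given here, the only exact number so far belongs to compound 2 `O=C(NNC(=O)c1cccc(Cl)c1)c1ccc(NS(=O)(=O)c2cnc(O)nc2O)cc1`, at 4160 nM.

Compound 3 `O=C(NNC(=O)c1ccccc1Cl)c1cccc(NS(=O)(=O)c2cnc(O)nc2O)c1` starts from compound 1 and carries (2-chlorophenyl)carbonyl in place of 2-fluorophenyl on an amine nitrogen. Among the compounds with values here, no measured step shows what this exchange does, so any forecast is uncertain. In this assay, a moderate shift toward stronger inhibition is expected, guided only by the value of compound 2 at 4160 nM. Compound 3 may still end up reported only as a limit. The expected change is an at least 2.2-fold lower number from compound 1 to compound 3 (0.34 log units; beyond the scatter). For compound 3 the estimated value is 9000 nM, with an expected range from 3000 nM to 20000 nM.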

Compound 3, half-maximal inhibitory concentration: 2360 nM
The estimate for compound 3 lay 3.8-fold (0.58 log units) above the measured number, and the stated range ends above it.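

In this assay, going by these compounds alone, putting (2-chlorophenyl)carbonyl in place of 2-fluorophenyl on this amine nitrogen gives the first readable change at this position: an at least 8.4-fold lower number from compound 1 to compound 3 (0.92 log units; beyond the scatter). The exchange alters two things at once, bringing in a carbonyl and replacing fluorine on the ring with chlorine, and this single step cannot separate their contributions. The true size of the step remains unknown because compound 1 is recorded only as a limit: the limit of > 20000 nM in this assay, at which 1 of the 3 values shown sits.

The compounds shown leave open whether the carbonyl or the chlorine matters more, a question that a (2-fluorophenyl)carbonyl group on the same nitrogen could help to answer. As far as these compounds go, it also remains open how an acetyl group, which keeps the carbonyl but has no aromatic ring, would read at this position.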